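The source may report more compounds than this note shows. Statements on the series, on what has been measured and on what is new or still open speak of the compounds shown alone.

Measured in a functional assay on A375P cells (Homo sapiens) for antiproliferative activity, read by MTT assay, with a stated time of 48 h; a higher number here means a weaker inhibitor, a lower number a stronger inhibitor:
compound 1 `Nc1cccc2c(-c3cccc(NC(=O)c4cc(C(F)(F)F)cc(C(F)(F)F)c4)c3)ccnc12`, 3400 nM
compound 2 `Nc1cccc2c(-c3cccc(NC(=O)c4ccc5c(c4)OCCO5)c3)ccnc12`, 860 nM
compound 3 `Cc1ccc(NC(=O)c2cc(C(F)(F)F)cc(C(F)(F)F)c2)cc1-c1ccnc2c(N)cccc12`, 7400 nM

Compound 2 gives the lowest of the three numbers, and its steps to both other compounds lie beyond the scatter. The difference between the cores of compound 1 and compound 2 is not broken down here. From compound 1 to compound 3 the change is methyl in place of hydrogen on an aromatic carbon, and it gave a 2.2-fold higher number from compound 1 to compound 3 (0.34 log units; beyond the scatter). Compound 4 `Cc1ccc(NC(=O)c2ccc3c(c2)OCCO3)cc1-c1ccnc2c(N)cccc12` carries the same kind of change on compound 2: methyl in place of hydrogen on an aromatic carbon. The place is described as ortho to a large group rather than ortho to a 8-aminoquinolin-4-yl group; otherwise the two place descriptions agree. The step expected in this assay is a 2.1-fold higher number from compound 2 to compound 4 (0.32 log units; beyond the scatter), because the only measured case of this change gave a 2.2-fold higher number from compound 1 to compound 3 (0.34 log units; beyond the scatter). In this assay compound 4 is therefore expected near 1800 nM, with a likely range from 900 nM to 3800 nM.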

Compound 4, half-maximal inhibitory concentration: 280 nM
For compound 4 the middle estimate is 6.4-fold (0.81 log units) above the measured one, outside the stated range (below it).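

In this assay, methyl in place of hydrogen on an aromatic carbon gave a 3.1-fold lower number from compound 2 to compound 4 (0.49 log units; beyond the scatter), so the change does not carry over between these two cores, even in direction: the same change on two cores in this assay, a 2.2-fold higher number (0.34 log units; beyond the scatter) from compound 1 to compound 3 and a 3.1-fold lower number (0.49 log units; beyond the scatter) from compound 2 to compound 4, 6.7-fold (0.83 log units) apart, beyond the scatter of two such steps The outcome of this change therefore depends on the core it is placed on, and a step measured on the core of compound 1 gives no safe reading for the core of compound 2. Two pairs do not show which part of the cores decides the outcome, or what the change would do on a further core.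

As far as these compounds go, it remains open whether ethyl or methoxy on the same aromatic carbon would follow methyl on each core. The same question applies to chlorine.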